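Swapping the benzyl group for an aminoethyl chain

This account rests on a few compounds, and the source may have more. Where it says the series, first, only, none or still open, it means among the compounds named here.

Of the compounds shown here, three sharing one core have been tested in an assay on isolated protein (Oryctolagus cuniculus) with Thromboxane-A synthase (Homo sapiens) as the target, tested at 1 uM; on this read-out higher numbers stand for more inhibition at the one concentration tested (going by the name of the read-out) and lower numbers for less inhibition. Compound 1 `Oc1nnc(-c2cccnc2)c2ccccc12` gives 26%. Compound 2 `CCCn1nc(-c2cccnc2)c2ccccc2c1=O`, which carries a propyl chain on the aromatic nitrogen, gives 86%. Compound 3 `O=c1c2ccccc2c(-c2cccnc2)nn1Cc1ccccc1` gives 97%, the highest of the three numbers; the nearest is compound 2, and the furthest is compound 1, both beyond the scatter.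

Compound 4 `NCCn1nc(-c2cccnc2)c2ccccc2c1=O` has not yet been measured. The change from compound 3 to compound 4 is aminomethyl in place of phenyl on a saturated chain carbon bound to an aromatic nitrogen. Among the compounds with values here, the only measured step at this position is a number 11 percentage points higher from compound 2 to compound 3 (beyond the scatter), where a phenyl replaced an ethyl on the same chain carbon. Compound 4 now gives up that phenyl again and gains an aminomethyl instead, so the gain seen in that step may be partly or wholly lost; nothing measured here speaks to the effect of the amino group itself. A moderate fall in this assay is therefore expected, roughly undoing the earlier step but with wide uncertainty.

The expected step is a number 25 percentage points lower from compound 3 to compound 4 (beyond the scatter), and compound 4 is estimated to give 72%, within a range from 50% to 90%.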

Compound 4, a percentage reported as inhibition, at one concentration (the size of the read-out at that concentration, not a potency): 29%
Compound 4: the middle estimate sits 43 percentage points above what was measured; measured number outside the range, below it.
By their numbers in this assay, from the lowest: compounds 1 and 4 (each within the scatter of the next); then compound 2; then compound 3.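

In this assay, the change from benzyl to 2-aminoethyl comes with a number 68 percentage points lower from compound 3 to compound 4 (beyond the scatter), so this position, where the earlier compounds had shown only a modest step, can also carry a large one. The comparison with the plain propyl chain is the more telling one: amino in place of methyl, on a saturated chain carbon two bonds along the chain from an aromatic nitrogen, gives a number 57 percentage points lower from compound 2 to compound 4 (beyond the scatter), which shows that losing the phenyl is not enough to account for the fall and that the amino group at the end of the chain goes with most of it. No information is available on what lies behind this fall.

The compounds shown leave open whether the fall is tied to the amine itself or would also appear with a hydroxyl or a carboxylic acid at the same chain end. They also leave open whether a dimethylamino group, or a longer chain carrying the amine further out, would give a similar number or recover some of the inhibition.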